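Swapping Amino for Methylsulfanyl on a Triazine Core

This account rests on a few compounds, and the source may have more. Where it says the series, first, only, none or still open, it means among the compounds named here.

Compound 1 `CNc1nc(NC2(C#N)CCCCC2)nc(OC)n1` gives 521 nM in an in vitro assay on Sf21 cells for inhibition of high affinity 3',5'-cyclic-AMP phosphodiesterase 7A (Homo sapiens); a lower number here means a stronger inhibitor, a higher number a weaker inhibitor. Compound 2 `CNc1nc(N)nc(NC2(C#N)CCCCC2)n1` shares that core but stands at "not determined" (no result reported) in this assay, so no figure places it. Compound 3 `CNc1nc(NC2(C#N)CCCCC2)nc(SC)n1` carries the change (methylsulfanyl in place of amino on an aromatic carbon). With no number for compound 2, no size or direction can be set for the step to compound 3 in this assay; the expectation rests on compound 1 alone, whose methoxy group sits where the methylsulfanyl group enters. Compound 3 is therefore expected to give about 400 nM, within 120 nM to 1500 nM, in this assay.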

Compound 3, half-maximal inhibitory concentration: 46 nM
Beside the measured number, compound 3's estimate is 8.7-fold (0.94 log units) above it; measured number below the stated range.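

Methylsulfanyl in place of methoxy on this aromatic carbon, opposite the ring nitrogen, brings an 11-fold lower number from compound 1 to compound 3 (1.05 log units; beyond the scatter) in this assay, so compound 3 is the stronger inhibitor and a change at this one position is enough to shift the result well beyond the scatter. The step from compound 2 to compound 3 cannot be read, as compound 2 has no number. Nothing measured here explains the gain. Still open, on these data alone, is whether ethylsulfanyl, a longer chain on the same sulfur, or a plain methyl group on this carbon would give a lower or a higher number.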